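This account rests on a few compounds, and the source may have more. Where it says the series, first, only, none or still open, it means among the compounds named here.

Measured in a functional assay on MCF7 cells (Homo sapiens) for antiproliferative activity, read by MTT assay, with a stated time of 96 h; a higher number here means a weaker inhibitor, a lower number a stronger inhibitor:

compound 1, `S=C(N/N=C1\CC2(CCCCC2)Oc2c1ccc1ccccc21)N1CCCCC1`: 13400 nM
compound 2, `S=C(N/N=C1\CC2(CCCCC2)Oc2c1ccc1ccccc21)N1CCNCC1`: 14200 nM
compound 3, `S=C(N/N=C1\CC2(CCCCC2)Oc2c1ccc1ccccc21)N1CCOCC1`: 11900 nM

Compound 3 gives the lowest of the three numbers, but its separation from the others is slight: a 1.1-fold lower number from compound 1 to compound 3 (0.05 log units; within the scatter) and a 1.2-fold lower number from compound 2 to compound 3 (0.08 log units; within the scatter) both lie within the scatter, as does a 1.1-fold higher number from compound 1 to compound 2 (0.03 log units; within the scatter). Going by the values given here, the three ring substituents on the thiocarbonyl carbon are therefore indistinguishable on these data, and no compound can be called more or less active than another.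

Compound 4, `NCCCCCCC(=S)N/N=C1\CC2(CCCCC2)Oc2c1ccc1ccccc21`, has not been measured. Its change from compound 3 is 6-aminohexyl in place of morpholin-4-yl on a thiocarbonyl carbon. Each measured step exchanges one six-membered ring for another on the same thiocarbonyl carbon and was flat; none of them opens the ring to a chain, so the measured steps bear on the new step only by showing that this position has so far tolerated variation without a shift beyond the scatter. Against that background, no step beyond the scatter is expected for compound 4, which is estimated at 12000 nM with a range of 4000 nM to 36000 nM. As far as these compounds go, the expected step from compound 3 is a 1.0-fold higher number from compound 3 to compound 4 (0.00 log units; within the scatter), with wider uncertainty than for the ring-to-ring exchanges because the chain is untested in this assay.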

Compound 4, half-maximal inhibitory concentration: 4970 nM
Estimate against measurement, compound 4: 2.4-fold (0.38 log units) above; the measured number falls inside the stated range.
By their numbers in this assay, from the lowest: compound 4; then compounds 3, 1 and 2 (each within the scatter of the next).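

In this assay, the position on the thiocarbonyl carbon no longer looks indifferent to its substituent: there is a 2.4-fold lower number from compound 3 to compound 4 (0.38 log units; beyond the scatter), with a 2.9-fold lower number from compound 2 to compound 4 (0.46 log units; beyond the scatter) and a 2.7-fold lower number from compound 1 to compound 4 (0.43 log units; beyond the scatter) alongside it, all three modest but beyond the scatter. Going by these compounds alone, the ring-to-ring exchanges among compounds 1, 2 and 3 showed no such separation, so replacing a six-membered ring with an open chain is the first change at this position to give a readable step, and compound 4 is the only compound here set apart from the others. This single change removes the ring, introduces the 6-aminohexyl chain and places a terminal amine on that chain, so the step belongs to the change as a whole and not to any one of these features; nothing measured here bears on the origin of the step.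

Still open, as far as these compounds go, is whether the chain or its terminal amine carries the step, which a plain hexyl chain on the same carbon would help to separate. A shorter aminoalkyl chain, a longer chain or a terminal carboxylic acid would show whether the number moves further with chain length or end group, or stays near that of compound 4.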